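Amine substituent exchange on the core of compound 3

The compounds below may be only part of what the source reports. "The series", "measured", "known", "first", "only" and "open" are said of these compounds alone.

Compound 3 `COCC(C)(C)Nc1nc(C)nc2c1nnn2-c1ccc(C(C)C)cc1Br` gives 195 nM in an in vitro assay on 293-EBNA cells for binding affinity to corticotropin-releasing factor receptor 1 (Homo sapiens) (a lower number here means a stronger inhibitor, a higher number a weaker inhibitor), the highest number among the three measured compounds. Compound 1 `Cc1nc(N2CCCC2)c2nnn(-c3ccc(C(C)C)cc3Br)c2n1` gives 194 nM, and the step of a 1.0-fold higher number from compound 1 to compound 3 (0.00 log units; within the scatter) lies within the scatter. Compound 2 `COCC(COC)Nc1nc(C)nc2c1nnn2-c1ccc(C(C)C)cc1Br` gives 10.3 nM, and the step of a 19-fold higher number from compound 2 to compound 3 (1.28 log units; beyond the scatter) is large. The step of a 19-fold lower number from compound 1 to compound 2 (1.27 log units; beyond the scatter) is large as well.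

Compound 4 `CCCCNc1nc(C)nc2c1nnn2-c1ccc(C(C)C)cc1Br` carries butyl in place of 1-(methoxymethyl)-1-methylethyl on a nitrogen on an aromatic ring. Among the measured compounds shown here, no measured step exchanges the group on this nitrogen for an unbranched chain, so guidance is indirect. Compound 2 and compound 3 show that the group on the ring nitrogen can shift the number by a large step in this assay, while compound 1 and compound 3 show two quite different groups landing on the same number. Butyl differs from all three groups seen so far, so a move back toward the number of compound 2 is plausible but not assured. The step of a 2.8-fold lower number from compound 3 to compound 4 (0.44 log units; beyond the scatter) is expected to be a moderate lowering of the number. Compound 4 is estimated at 70 nM, with a range from 15 nM to 300 nM.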

Compound 4, inhibition constant: 69.6 nM
Compound 4: the middle estimate sits 1.0-fold (0.00 log units) above what was measured; the range from low to high includes it.
By their numbers in this assay, from the lowest: compound 2; then compound 4; then compounds 1 and 3 (each within the scatter of the next).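

In this assay the butyl group on this nitrogen gives a 2.8-fold lower number from compound 3 to compound 4 (0.45 log units; beyond the scatter) as the step for replacing 1-(methoxymethyl)-1-methylethyl, so a group with no oxygen and no hydrogen-bond acceptor is compatible with a lower number here. Butylamino in place of pyrrolidin-1-yl gives a 2.8-fold lower number from compound 1 to compound 4 (0.45 log units; beyond the scatter) and thus separates these two groups. Butyl still falls short of the 2-methoxy-1-(methoxymethyl)ethyl group, with a 6.8-fold higher number from compound 2 to compound 4 (0.83 log units; beyond the scatter) as the step, which places this change between the earlier extremes.

Compounds 2 and 4 differ in both branching and oxygen content, so the share of each in that step stays unresolved. A pentyl chain or a 2-methoxyethyl group on this nitrogen would bear on that question.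

No measurement at hand accounts for any of these steps.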